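The source may hold more compounds than are shown below. What is called first, only, known or untested is meant among the compounds shown, and "the series" means these compounds.

In an ADME assay on cells (Homo sapiens) for cytotoxicity, read by resazurin assay, with a stated time of 5 days (on this read-out higher numbers stand for lower toxicity in this test and lower numbers for higher toxicity in this test), compound 1, `O=S(=O)(Cc1nc(-c2ccncc2)c2sccc2n1)c1cccc(Cl)c1`, gives > 50000 nM, which is a limit of the assay rather than a number. Compound 2, `O=S(=O)(Cc1nc(-c2ccoc2)c2sccc2n1)c1cccc(Cl)c1`, gives in this assay > 50000 nM, again a limit. Compound 3, `O=S(=O)(Cc1nc(-c2cccnc2)c2sccc2n1)c1cccc(Cl)c1`, gives in this assay > 50000 nM, also a limit. The step that the two limits leave unreadable from compound 1 to compound 2 cannot be sized; both of its values are limits. The same holds for the step that the two limits leave unreadable from compound 1 to compound 3 and for the step that the two limits leave unreadable from compound 2 to compound 3. Compound 3 therefore stands where the other two stand, at the limit of > 50000 nM in this assay, at which 3 of the 3 values shown sit.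

Compound 4, `O=c1ccc(-c2nc(CS(=O)(=O)c3cccc(Cl)c3)nc3ccsc23)c[nH]1`, differs from compound 3 in one place: a group of 7 heavy atoms (5 carbon, 1 nitrogen, 1 oxygen; one six-membered aromatic ring with 1 hetero atom) in place of a group of 6 heavy atoms (5 carbon, 1 nitrogen; one six-membered aromatic ring with 1 hetero atom), on an aromatic carbon. For the measured compounds named here, the measured steps that end at compound 3, the one from compound 1 and the one from compound 2, both sit at the limit on either side, so they give no readable size and no direction; they show only that changes of the group at this position have not brought toxicity into the measurable range. Compound 4 is expected to behave likewise in this assay, so that the step that the limit leaves unreadable from compound 3 to compound 4 is expected to be none beyond the scatter. For compound 4 the estimate in this assay is 60000 nM, within a range from 30000 nM to 120000 nM, most probably reported again as a limit.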

Compound 4, half-maximal cytotoxic concentration: > 50000 nM
Compound 4 was reported as a limit (the forecaster's own chance of this, stated with the estimate: 85%); the middle value does not contradict the limit.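

In this assay compound 4 gives > 50000 nM, again a limit. For the compounds shown here, no step from compound 1, compound 2 or compound 3 to compound 4 can be read, as all four compounds share one limit: the limit of > 50000 nM in this assay, at which 4 of the 4 values shown sit. The compounds shown leave open whether any group at this position brings toxicity into the measurable range of this assay.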